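The compounds below may be only part of what the source reports. "The series", "measured", "known", "first", "only" and "open" are said of these compounds alone.

Measured in an ADME assay on BJ cells (Homo sapiens) for cytotoxicity, with a stated time of 72 h; a higher number here means that more compound is needed for the effect, a lower number that less compound is needed:

Compound 1 `Cc1cc(NC(=O)Nc2cccc(C(N)=O)c2)c2ccccc2n1`: > 25000 nM (a limit)
Compound 2 `COC(=O)c1cccc(NC(=O)Nc2cc(C)nc3ccccc23)c1`: 21000 nM
Compound 3 `Cc1cc(NC(=O)Nc2cccc(N(C)C)c2)c2ccccc2n1`: > 25000 nM (a limit)

Compound 3 gives > 25000 nM, which is a limit and not a number. It thus sits at the limit of > 25000 nM in this assay, at which 2 of the 3 values shown sit.

The next compound, compound 4 `Cc1cc(NC(=O)Nc2cccc(C(C)(C)C)c2)c2ccccc2n1`, carries tert-butyl in place of dimethylamino on an aromatic carbon, meta to a large group: tert-butyl in place of dimethylamino on an aromatic carbon.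

For the measured compounds named here, no measured step makes this exact exchange. Going by the values given here, the steps that bear on it are an at least 1.1-fold higher number from compound 2 to compound 3 (0.07 log units; that floor lies within the scatter) and an at least 1.1-fold lower number from compound 1 to compound 2 (0.07 log units; that floor lies within the scatter), and both are only floors within the scatter. The third, a step that the two limits leave unreadable from compound 1 to compound 3, cannot be sized at all. Compound 1, compound 2 and compound 3 therefore show no step beyond the scatter in this assay, and none beyond the scatter is expected here. Compound 4 may well report only a limit again.

Compound 4 is expected at about 22000 nM, with an estimated range from 10000 nM to 45000 nM. The estimated step is an at least 1.1-fold lower number from compound 3 to compound 4 (0.05 log units; that floor lies within the scatter).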

Compound 4, half-maximal effective concentration: > 25000 nM
Compound 4 ended at the assay's limit; the forecaster's own chance of this, stated with the estimate: 55%; middle value at least 1.1-fold (0.05 log units) away from the limit.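

In this assay, for the compounds shown here, an all-carbon group in this place, tert-butyl with no hydrogen-bond acceptor, leaves compound 4 at the same limit as compound 1 and compound 3, whereas the earlier compounds carried only groups with nitrogen or oxygen here: the limit of > 25000 nM in this assay, at which 3 of the 4 values shown sit. Going by these compounds alone, the one readable comparison is an at least 1.1-fold higher number from compound 2 to compound 4 (0.07 log units; that floor lies within the scatter), so compound 2 remains the only compound with a measured number, and the floor on its gap to compound 4 does not separate the two. The steps from compound 1 and from compound 3 to compound 4 cannot be read, since both ends of each are limits.

The compounds shown leave open how far any of the three limit compounds lies from a measurable value. They also leave open whether a carboxylic acid, an amine or a longer chain in this place would give a number rather than a limit.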